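A few compounds are considered here, and "the series" means these few. Any claim that something is new, unique, unknown or untested is made for them only; others in the source may bear on it.

Measured so far:
- Compound 1, `CC(C)Nc1nc(Nc2ccc(S(N)(=O)=O)cc2)ncc1/N=C/c1ccccc1`: > 100000 nM
- Compound 2, `CC(C)Nc1nc(Nc2ccc(S(N)(=O)=O)cc2)ncc1/N=C/c1cccs1`: > 100000 nM

In a functional assay on HeLa cells (Homo sapiens) for antiproliferative activity, read by MTT assay (on this read-out higher numbers stand for weaker inhibition and lower numbers for stronger inhibition), compound 1 gives > 100000 nM, which is a limit of the assay and not a number. Compound 2 gives > 100000 nM in this assay, again a limit. Within the data shown here, both values therefore sit at the limit of > 100000 nM in this assay, at which 2 of the 2 values shown sit, and the only step between them, a step that the two limits leave unreadable from compound 1 to compound 2, cannot be read. Compound 3, `CC(C)Nc1nc(Nc2ccc(S(N)(=O)=O)cc2)ncc1/N=C/c1ccc(C(F)(F)F)cc1`, differs from compound 2 by 4-(trifluoromethyl)phenyl in place of thiophen-2-yl on a carbon with a double bond to nitrogen. Among the measured compounds shown here, no measured step gives a direction for this change, so compound 3 is expected to remain near the same limit. Compound 3 is estimated at 100000 nM, with a range from 30000 nM to 300000 nM, meaning an expected step of a number no higher from compound 2 to compound 3 (the limit leaves the size open).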

Compound 3, half-maximal inhibitory concentration: > 100000 nM
Compound 3 was reported as a limit (the forecaster's own chance of this, stated with the estimate: 85%); the middle value lies on the limit itself.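

In this assay compound 3 gives > 100000 nM, a limit and not a number. Among these compounds, no step among compound 1, compound 2 and compound 3 can be read: the limit of > 100000 nM in this assay, at which 3 of the 3 values shown sit. The compounds shown leave open whether any group on the carbon with a double bond to nitrogen would give a readable value in this assay.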